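This account rests on a few compounds, and the source may have more. Where it says the series, first, only, none or still open, it means among the compounds named here.

Series notes, cytotoxicity. Compound 1 `COc1ccc(C(=O)CCN2CCN(c3ccc(C(F)(F)F)cc3)CC2)cc1` gives 135000 nM in an ADME assay on Vero cells (Chlorocebus sabaeus) for cytotoxicity, read by resazurin assay, with a stated time of 72 h; a lower number here means a stronger inhibitor, a higher number a weaker inhibitor. Compound 2 `COc1ccc(C(=O)CCN2CCN(c3ccc(Cl)cc3)CC2)cc1` gives 300000 nM in this assay, and compound 3 `O=C(CCN1CCN(c2ccc(C(F)(F)F)cc2)CC1)c1ccc(C(F)(F)F)cc1` gives 49200 nM in this assay, the lowest of the three numbers. The change from compound 1 to compound 2, (chloro in place of trifluoromethyl on an aromatic carbon), gave a 2.2-fold higher number from compound 1 to compound 2 (0.35 log units; beyond the scatter). The change from compound 1 to compound 3, (trifluoromethyl in place of methoxy on an aromatic carbon), gave a 2.7-fold lower number from compound 1 to compound 3 (0.44 log units; beyond the scatter); this is also how the core of compound 3 differs from that of compound 1.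

Compound 4 `O=C(CCN1CCN(c2ccc(Cl)cc2)CC1)c1ccc(C(F)(F)F)cc1` is not yet measured in this assay. It differs from compound 3 by chloro in place of trifluoromethyl on an aromatic carbon, the same change already seen from compound 1 to compound 2, occurring twice in all among these compounds, at a place described in the same words both times.

Going by the values given here, from compound 3 to compound 4 a step of a 2.1-fold higher number from compound 3 to compound 4 (0.33 log units; beyond the scatter) is expected, close in size to the earlier one, because a 2.2-fold higher number from compound 1 to compound 2 (0.35 log units; beyond the scatter) is the only measured instance of this change. Compound 4 is therefore estimated at 105000 nM, with a likely range from 50000 nM to 220000 nM, pending measurement.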

Compound 4, half-maximal inhibitory concentration: 54200 nM
For compound 4 the middle estimate is 1.9-fold (0.29 log units) above the measured one; the measured number falls inside the stated range.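

In this assay, chloro in place of trifluoromethyl on an aromatic carbon gives a 1.1-fold higher number from compound 3 to compound 4 (0.04 log units; within the scatter), and the two instances of this change cannot be told apart: the same change on two cores in this assay, a 2.2-fold higher number (0.35 log units; beyond the scatter) from compound 1 to compound 2 and a 1.1-fold higher number (0.04 log units; within the scatter) from compound 3 to compound 4, 2.0-fold (0.30 log units) apart, within the scatter of two such steps Trifluoromethyl in place of methoxy on an aromatic carbon gives a 5.5-fold lower number from compound 2 to compound 4 (0.74 log units; beyond the scatter), which also cannot be told apart from its earlier instance: the same change on two cores in this assay, a 2.7-fold lower number (0.44 log units; beyond the scatter) from compound 1 to compound 3 and a 5.5-fold lower number (0.74 log units; beyond the scatter) from compound 2 to compound 4, 2.0-fold (0.30 log units) apart, within the scatter of two such steps Both changes therefore carry between these two cores without a gap beyond the scatter, and the methoxy change lowers the number beyond the scatter on both, whereas only the step from compound 1 to compound 2 shows the chloro change beyond the scatter, so no consistent direction is shown for it, and four compounds forming two pairs of cores do not establish a rule for the wider series.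

The compounds shown leave open whether either change would carry onto a core bearing a different group on that aromatic carbon, such as a nitrile or an amine, or onto one with a longer linking chain. They also leave open whether the same agreement would hold in any read-out other than this assay.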